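Three assay limits, one more analogue still to be measured

The source may report more compounds than this note shows. Statements on the series, on what has been measured and on what is new or still open speak of the compounds shown alone.

Measured so far:
compound 1, `COc1cccc(/C=C/C(=O)c2sc(Nc3ccc(Cl)cc3)nc2C)c1`: > 25000 nM
compound 2, `Cc1nc(Nc2ccc(Cl)c(Cl)c2)sc1C(=O)/C=C/c1ccc(Cl)cc1`: > 25000 nM
compound 3, `COc1cccc(/C=C/C(=O)c2sc(Nc3ccccc3C)nc2C)c1`: > 25000 nM

In a functional assay on NCI-H460 cells (Homo sapiens) for cytotoxicity, read by MTT assay (on this read-out lower numbers stand for stronger inhibition and higher numbers for weaker inhibition), compound 3 gives only a limit, > 25000 nM, not a number. Compound 3 therefore stands at the limit of > 25000 nM in this assay, at which 3 of the 3 values shown sit, so its place among the measured compounds cannot be ranked. For the measured compounds named here, the one measured step that touches it, a step that the two limits leave unreadable from compound 1 to compound 3, is also unreadable, as both ends are limits.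

Compound 4, `COc1cccc(/C=C/C(=O)c2sc(Nc3ccc(Cl)c(Cl)c3)nc2C)c1`, is not yet measured. It differs from compound 3 in one place: 3,4-dichlorophenyl in place of 2-methylphenyl on a nitrogen on an aromatic ring. No measured step covers this particular change, so its size cannot be read from what is shown. Compound 2 carries the same 3,4-dichlorophenyl group and in this assay gives a limit, > 25000 nM. Going by the values given here, because every value so far sits at the limit of > 25000 nM in this assay, at which 3 of the 3 values shown sit, the step that the limit leaves unreadable from compound 3 to compound 4 is expected to end at the limit as well. Compound 4 is estimated at 40000 nM, within a range from 15000 nM to 100000 nM.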

Compound 4, half-maximal inhibitory concentration: 20100 nM
Compound 4: the middle estimate sits 2.0-fold (0.30 log units) above what was measured; measured number inside the range.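

In this assay, compound 4 is the one compound shown that gives a number rather than a limit: the limit of > 25000 nM in this assay, at which 3 of the 4 values shown sit.

At the place on the nitrogen, 3,4-dichlorophenyl in place of 2-methylphenyl gives an at least 1.2-fold lower number from compound 3 to compound 4 (0.09 log units; that floor lies within the scatter) and chloro in place of hydrogen on an aromatic carbon gives an at least 1.2-fold lower number from compound 1 to compound 4 (0.09 log units; that floor lies within the scatter), so this pair of chloro groups, with 3-methoxyphenyl on the chain, is the one combination shown that comes inside the readable range. On these data alone, changing 4-chlorophenyl to 3-methoxyphenyl on the double-bonded chain gives an at least 1.2-fold lower number from compound 2 to compound 4 (0.09 log units; that floor lies within the scatter), and as each step is only a floor, its true size stays unknown.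

As far as these compounds go, whether a nitrile or a carboxylic acid on the phenyl ring at that nitrogen would give a lower number than compound 4 stays open. So does the effect of an amine on the ring at the end of the chain.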